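The compounds below may be only part of what the source reports. "The series", "measured", "known", "first", "only" and "open" are said of these compounds alone.

Working notes on the series.

Compound 1 `COc1cc(-c2cc(/C=C/C(=O)c3ccc(N)cc3)[nH]n2)cc(OC)c1OC` sits at the low end of the two numbers recorded so far. In a functional assay on SK-MEL-5 cells (Homo sapiens) for cytotoxicity, read by sulforhodamine B assay, with a stated time of 48 h, tested at 10 uM (a higher number here means a weaker effect of the compound at the concentration tested, a lower number a stronger effect), compound 1 gives -95%. Among the measured compounds shown here, compound 2 `COc1ccc(-c2cc(/C=C/C(=O)c3ccc(OC)c(OC)c3)[nH]n2)cc1` is the only other measured member; in this assay compound 2 gives -66%, a number that lies above that of compound 1 by more than the usual scatter, so the two values show a real separation with compound 1 as the lower of the pair. For the measured compounds named here, no pair of measured compounds differs in a single place, so no measured step is available for the change now under consideration.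

Compound 3 `COc1cc(-c2cc(/C=C/C(=O)c3ccc(Cl)c(Cl)c3)[nH]n2)cc(OC)c1OC` is the next member to be run in this assay. Relative to compound 1 it carries the change (3,4-dichlorophenyl in place of 4-aminophenyl on a carbonyl carbon).

Going by the values given here, with no single-point step measured, the direction of this change can only be estimated. The expectation is a modest move toward a weaker effect, a number 15 percentage points higher from compound 1 to compound 3 (beyond the scatter), though a shift that stays within the scatter is also plausible. Compound 3 is expected to give about -80% in this assay, within a range from -100% to -45%.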

Compound 3, a percentage reported as activity, at one concentration (the size of the read-out at that concentration, not a potency): 62%
Compound 3: the middle estimate sits 142 percentage points below what was measured, and the stated range ends below it.
By their numbers in this assay, from the lowest: compound 1; then compound 2; then compound 3.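

In this assay the group on the carbonyl carbon turns out to be a decisive point of the series: with the rest of the core of compound 1 unchanged, 3,4-dichlorophenyl in place of 4-aminophenyl gives a number 157 percentage points higher from compound 1 to compound 3 (beyond the scatter) and no small adjustment. Among the compounds shown here, this is the first single-place step available, and it shows that this one change is enough to move the read-out from the negative side, with compound 1 at -95%, to the positive side, with compound 3 at 62%, a far weaker effect at the concentration tested. Nothing to hand accounts for the size of this step, so it stands as an observation only.

The change removes the amino group and adds two chlorines in a single move, so the step cannot be divided between the loss of one and the gain of the other. Open too, going by these compounds, is whether an unsubstituted phenyl, a monochlorophenyl, a hydroxyphenyl or a dimethylaminophenyl on the same carbonyl carbon would give a number close to that of compound 1 or close to that of compound 3.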